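Series notes: from compound 3 to compound 4

A few compounds are considered here, and "the series" means these few. Any claim that something is new, unique, unknown or untested is made for them only; others in the source may bear on it.

Readings so far in a physicochemical assay for lipophilicity, measured as octanol-water partition (on this read-out lower numbers stand for lower lipophilicity and higher numbers for higher lipophilicity), are these
- compound 1 (`COc1ccc(/C=N/NC(=O)COc2cccc3ccccc23)cc1OC`) at 3.51
- compound 2 (`O=C(COc1cccc2ccccc12)N/N=C/c1ccccc1`) at 4.02
- compound 3 (`O=C(COc1cccc2ccccc12)N/N=C/c1cccc(Br)c1`) at 4.81

Compound 3 holds the highest of the three numbers, with compound 2 the nearest to it and compound 1 the furthest. The next compound to be read is compound 4 (`COc1ccc(/C=N/NC(=O)COc2cccc3ccccc23)cc1`). It carries 4-methoxyphenyl in place of 3-bromophenyl on a carbon with a double bond to nitrogen, so the bromo is lost and a methoxy is gained in one change.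

Among the compounds with values here, only one measured single-site step bears on this, a number 0.79 log units higher from compound 2 to compound 3 (beyond the scatter) with bromo in place of hydrogen on an aromatic carbon. Removing the bromo is expected to give back a step of about that size, downward. Within the data shown here, no step for a single methoxy has been measured. The closest guide is compound 1 at 3.51 and its lower number than compound 2 at 4.02, which suggests that the methoxy adds a further small fall rather than a rise. The estimated move is a number 1.01 log units lower from compound 3 to compound 4 (beyond the scatter) and so somewhat larger than the bromo step. For compound 4 the estimated value is 3.8, with an expected range of 3.45 to 4.15.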

Compound 4, partition coefficient: 3.77
Compound 4: middle estimate off by 0.03 log units, on the high side, and the stated range covers the measured number.
By their numbers in this assay, from the lowest: compounds 1, 4 and 2 (each within the scatter of the next, the first and the last beyond it); then compound 3.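

In this assay, within the data shown here, replacing 3-bromophenyl with 4-methoxyphenyl on the carbon with a double bond to nitrogen gives a number 1.04 log units lower from compound 3 to compound 4 (beyond the scatter), the first step to be classed as large and the first to exchange one substituted phenyl directly for another. Among these compounds, the methoxy can now be read on its own for the first time, and both single-site steps, a number 0.25 log units lower from compound 2 to compound 4 (within the scatter) and a number 0.26 log units higher from compound 1 to compound 4 (within the scatter), stay within the scatter, so neither resolves a methoxy step and the large exchange cannot be placed on the methoxy alone. No measurement available here bears on why these numbers fall as they do.

Because the exchange alters both the group and its place on the phenyl ring, the compounds shown do not separate the contribution of the group from that of its place. Among the compounds shown here, it also remains open how this read-out would respond to an amine, a carboxylic acid or a longer alkoxy chain on the same phenyl ring, as the series so far covers only hydrogen, bromo and methoxy.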